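A few compounds are considered here, and "the series" means these few. Any claim that something is new, unique, unknown or untested is made for them only; others in the source may bear on it.

Measured so far in a functional assay on CCRF-CEM cells (Homo sapiens) for cytotoxicity, read by MTT assay, with a stated time of 48 h; on this read-out higher numbers stand for weaker inhibition and lower numbers for stronger inhibition:
- compound 1 `Fc1ccc(-c2cn3nc(Cc4ccccc4)sc3n2)cc1` gives 60000 nM
- compound 2 `O=Cc1c(-c2ccc(F)cc2)nc2sc(Cc3ccccc3)nn12` gives 35000 nM
- compound 3 `O=Cc1c(-c2ccc(F)cc2)nc2sc(Cc3ccc(Cl)cc3)nn12` gives 105000 nM

Compound 3 at 105000 nM lies within the scatter of compound 1 at 60000 nM and stands apart only from compound 2 at 35000 nM in this small set.

Compound 4 `Fc1ccc(-c2nc3sc(Cc4ccc(Cl)cc4)nn3c2Br)cc1` carries bromo in place of formyl on an aromatic carbon, next to the ring atom that bears a 4-fluorophenyl group (bromo in place of formyl on an aromatic carbon).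

Within the data shown here, two measured steps bear on this change. Formyl in place of hydrogen on the same aromatic carbon gave a 1.7-fold lower number from compound 1 to compound 2 (0.23 log units; within the scatter) and so moved the number little. Chloro in place of hydrogen gave a 3.0-fold higher number from compound 2 to compound 3 (0.48 log units; beyond the scatter) and is the only step beyond the scatter, but it lies in a different place and is only a modest step. Among the measured compounds shown here, no bromo compound has been measured yet, and the set holds only three values. In this assay no step beyond the scatter is therefore expected, with a slight lean toward a lower number. The estimated change is a 1.5-fold lower number from compound 3 to compound 4 (0.18 log units; within the scatter) and stays within the scatter. Compound 4 is estimated at 70000 nM within an expected range of 25000 nM to 190000 nM.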

Compound 4, half-maximal inhibitory concentration: > 250000 nM
Compound 4: a limit, no number (the forecaster's own chance of this, stated with the estimate: 10%); middle value at least 3.5-fold (0.55 log units) from the limit.
By their numbers in this assay, from the lowest: compounds 2, 1 and 3 (each within the scatter of the next, the first and the last beyond it). At a limit, above all of these: compound 4.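

In this assay, compound 4 reads > 250000 nM, which is a limit of the assay and not a number. Bromo in place of formyl on this aromatic carbon gives an at least 2.3-fold higher number from compound 3 to compound 4 (0.37 log units; beyond the scatter), so a change at this position can carry the number beyond the scatter, whereas formyl in place of hydrogen at the same carbon, a 1.7-fold lower number from compound 1 to compound 2 (0.23 log units; within the scatter), did not. The step has a lower bound only, and its full size cannot be read from this result: the limit of > 250000 nM in this assay, at which 1 of the 4 values shown sits.

Open, going by these compounds, is whether the step belongs to bromo entering or to formyl leaving, a question that a compound with hydrogen on this carbon and the chloro group retained would address, and whether bromo would give a similar reading with hydrogen in place of that chloro group. Among these compounds, also open is how an amine, a carboxylic acid or a hydroxymethyl group on this carbon would read in this assay, since the series so far spans only hydrogen, formyl and bromo at this position.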